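The source may hold more compounds than are shown below. What is called first, only, known or untested is meant among the compounds shown, and "the series" means these compounds.

Of the compounds shown here, two have been measured so far. In an assay on CHO cells for displacement of a labelled ligand from prostaglandin D2 receptor 2 (Homo sapiens), read by scintillation counting (on this read-out lower numbers stand for stronger inhibition and higher numbers for weaker inhibition), compound 2 `CS(=O)(=O)c1ccc(F)c(C#Cc2cc(Cl)ccc2OCC(=O)O)c1` gives 3.3 nM, the lower of the two numbers shown, while compound 1 `Cc1ccc(S(=O)(=O)N(C)CC(C)C)cc1C#Cc1cc(Cl)ccc1OCC(=O)O` gives 4.2 nM; the gap between them lies within the scatter, so neither can be called the more potent. Compound 3 `O=C(O)COc1ccc(Cl)cc1C#Cc1cc(CO)ccc1F` has not yet been measured. It differs from compound 2 in one place: hydroxymethyl in place of methylsulfonyl on an aromatic carbon. Among the measured compounds shown here, no measured pair shows this same change, so there is no direct guide to its effect. A modest step toward a higher number, just beyond the scatter, is expected: a 4.5-fold higher number from compound 2 to compound 3 (0.66 log units; beyond the scatter). Compound 3 is therefore estimated at 15 nM, with a likely range from 4 nM to 60 nM.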

Compound 3, inhibition constant: 73 nM
The estimate for compound 3 lay 4.9-fold (0.69 log units) below the measured number, outside the stated range (above it).
By their numbers in this assay, from the lowest: compounds 2 and 1 (each within the scatter of the next); then compound 3.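

Replacing methylsulfonyl with hydroxymethyl on this aromatic carbon, para to a fluoro group, gives a 22-fold higher number from compound 2 to compound 3 (1.34 log units; beyond the scatter) in this assay and so weaker inhibition. Among the compounds shown here, this position is therefore sensitive to what it carries, which the earlier compounds could not show. The change removes two double bonds and adds a hydrogen-bond donor, but nothing measured here says which difference matters or explains the size of the step.

Still open, going by these compounds, is how a nitrile, an amide or a longer chain at this position would compare with methylsulfonyl and hydroxymethyl.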